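Alkyl growth on the aromatic carbon: solubility working notes

The source may report more compounds than this note shows. Statements on the series, on what has been measured and on what is new or still open speak of the compounds shown alone.

Compound 1 `CCCN(CCC)CCNc1n[n+]([O-])c2ccc(C)cc2[n+]1[O-]` and compound 2 `CCCN(CCC)CCNc1n[n+]([O-])c2ccc(C(C)C)cc2[n+]1[O-]` share one core and differ in the group on an aromatic carbon. In a physicochemical assay for solubility, in the presence of a further agent that is not named here (a lower number here means a less soluble compound, a higher number a more soluble compound), compound 1 gives 38000000 nM, and compound 2 gives 39000000 nM. The step of a 1.0-fold higher number from compound 1 to compound 2 (0.01 log units; within the scatter) is within the scatter, so compound 2 stands level with compound 1 and no ordering between the two can be read from these numbers. Compound 3 `CCCN(CCC)CCNc1n[n+]([O-])c2ccc(C(C)(C)C)cc2[n+]1[O-]` carries the change (methyl in place of hydrogen on a saturated chain carbon bound to an aromatic carbon and two saturated chain carbons); cut one bond further out, the same difference reads isopropyl to tert-butyl. Among the compounds with values here, the only measured step that bears on it is a 1.0-fold higher number from compound 1 to compound 2 (0.01 log units; within the scatter), which was itself within the scatter for a change of the same kind on the same aromatic carbon. No movement beyond the scatter is therefore expected in this assay, an estimated step of no change at the digits printed from compound 2 to compound 3 (within the scatter). Compound 3 is estimated at 39000000 nM, with a range from 20000000 nM to 75000000 nM.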

Compound 3, solubility: 32000000 nM
Compound 3: middle estimate off by 1.2-fold (0.09 log units), on the high side, and the stated range covers the measured number.
By their numbers in this assay, from the lowest: compounds 3, 1 and 2 (each within the scatter of the next).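

In this assay the step of a 1.2-fold lower number from compound 2 to compound 3 (0.09 log units; within the scatter) comes with methyl in place of hydrogen on a saturated chain carbon bound to an aromatic carbon and two saturated chain carbons, and the step of a 1.2-fold lower number from compound 1 to compound 3 (0.07 log units; within the scatter) comes with tert-butyl in place of methyl on an aromatic carbon. The level reading on this aromatic carbon, earlier seen only from methyl to isopropyl, now extends to tert-butyl, so compounds 1, 2 and 3 cannot be ordered by these numbers. No supporting measurement is available to account for this reading.

From the compounds shown here alone, these compounds cover only branched or simple alkyl groups at this position, so a longer chain, an amine or a carboxylic acid on the same aromatic carbon remains open. Going by these compounds, whether any such group would move the number beyond the scatter also remains open.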